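Nitrogen substituents: from compound 3 to compound 4

The compounds below may be only part of what the source reports. "The series", "measured", "known", "first", "only" and "open" are said of these compounds alone.

In a functional assay on K562 cells (Homo sapiens) for cytotoxicity, read by trypan blue exclusion, with a stated time of 96 h (on this read-out lower numbers stand for stronger inhibition and higher numbers for weaker inhibition), compound 1 `COc1cc(OC)c(/C=C/S(=O)(=O)Cc2ccc(OC)c(N)c2)c(OC)c1` gives 2.5 nM, compound 2 `COC(=O)CCNc1cc(CS(=O)(=O)/C=C/c2c(OC)cc(OC)cc2OC)ccc1OC` gives 1000 nM and compound 3 `COC(=O)C(Nc1cc(CS(=O)(=O)/C=C/c2c(OC)cc(OC)cc2OC)ccc1OC)c1ccc(Cl)cc1` gives 200 nM, the middle of the three numbers. Next is compound 4 `COc1cc(OC)c(/C=C/S(=O)(=O)Cc2ccc(OC)c(NCCC(=O)O)c2)c(OC)c1`: 2-carboxyethyl in place of (4-chlorophenyl)(methoxycarbonyl)methyl on a nitrogen on an aromatic ring. Both substitutions on that nitrogen gave large steps, a 400-fold higher number from compound 1 to compound 2 (2.60 log units; beyond the scatter) and an 80-fold higher number from compound 1 to compound 3 (1.90 log units; beyond the scatter). The step between the two substituents was modest, a 5.0-fold lower number from compound 2 to compound 3 (0.70 log units; beyond the scatter). Within the data shown here, no measured step covers a free acid in place of the ester of compound 2, so compound 4 is expected to stay within the range of the substituted compounds. The expected change is small, a 1.5-fold higher number from compound 3 to compound 4 (0.18 log units; within the scatter), with no step beyond the scatter. For compound 4 the estimate is 300 nM, with an expected range of 40 nM to 2000 nM.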

Compound 4, half-maximal inhibitory concentration: 5000 nM
Compound 4: the middle estimate sits 17-fold (1.22 log units) below what was measured; the whole stated range lies below it.
By their numbers in this assay, from the lowest: compound 1; then compound 3; then compound 2; then compound 4.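

In this assay, hydrogen in place of methyl on the ester oxygen gives a 5.0-fold higher number from compound 2 to compound 4 (0.70 log units; beyond the scatter) as the first step read at the ester itself, so the free acid ranks below the ester on this nitrogen. Against the unsubstituted amine, 2-carboxyethyl gives a 2000-fold higher number from compound 1 to compound 4 (3.30 log units; beyond the scatter) as the largest step in the series, and against the (4-chlorophenyl)(methoxycarbonyl)methyl group it gives a 25-fold higher number from compound 3 to compound 4 (1.40 log units; beyond the scatter) as a large loss. No measurement available here accounts for these steps.

Still open, going by these compounds, is whether a small alkyl group such as methyl on this nitrogen keeps the activity of compound 1. Also open, on these data alone, is how a primary amide or a longer chain ending in a carboxylic acid would compare with 2-carboxyethyl.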